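Low HepG2 toxicity across the series: the aromatic nitrogen methyl

The source may hold more compounds than are shown below. What is called first, only, known or untested is meant among the compounds shown, and "the series" means these compounds.

Values in a toxicity assay on HepG2 cells (Homo sapiens) for inhibition, read by resazurin assay, with a stated time of 24 h (a lower number here means that less compound is tolerated, a higher number that more compound is tolerated), are as follows
Compound 1 (`CC(NC(=O)c1ncc([N+](=O)[O-])n1C)c1ccc(F)cc1`) gives > 100000 nM
Compound 2 (`Cn1c([N+](=O)[O-])cnc1C(=O)NCc1ccccn1`) gives > 100000 nM
Compound 3 (`O=C(NCc1cccc(OC(F)(F)F)c1)c1ncc([N+](=O)[O-])[nH]1`) gives > 100000 nM

Compound 2 gives > 100000 nM in this assay and this is a limit of the assay, not a number. It does not stand apart from the other two measured compounds (the limit of > 100000 nM in this assay, at which 3 of the 3 values shown sit).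

Compound 4 (`O=C(NCc1ccccn1)c1ncc([N+](=O)[O-])[nH]1`) differs from compound 2 by a single change (hydrogen in place of methyl on an aromatic nitrogen), hydrogen in place of methyl on an aromatic nitrogen. For the measured compounds named here, no measured pair isolates this change. The expectation leans on compound 3, which carries hydrogen on the aromatic nitrogen and gives > 100000 nM as a limit too. No step beyond the usual scatter is expected in this assay, and no direction is favoured. The estimated step (a number no higher from compound 2 to compound 4 (the limit leaves the size open)) stays within that scatter. For compound 4 the estimated half-maximal cytotoxic concentration is 100000 nM with an expected range from 50000 nM to 200000 nM and a report as a limit is the likeliest outcome.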

Compound 4, half-maximal cytotoxic concentration: > 100000 nM
Compound 4 was reported as a limit (the forecaster's own chance of this, stated with the estimate: 80%); the middle value sits exactly at the limit.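

In this assay no step can be read between compound 2 and compound 4, since both stand as limits of the assay: the limit of > 100000 nM in this assay, at which 4 of the 4 values shown sit. The compounds shown leave open at what concentration any of them becomes cytotoxic, and whether hydrogen or methyl on the aromatic nitrogen matters there.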